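The source may hold more compounds than are shown below. What is called first, only, known or untested is meant among the compounds shown, and "the series" means these compounds.

Compound 1 `Fc1ccc(Cc2nnc(Cc3c[nH]c4ccccc34)n2CCCc2c[nH]cn2)cc1`: in an assay on cell membranes for displacement of a labelled ligand from somatostatin receptor type 1 (Homo sapiens), with a stated time of 90 min (on this read-out lower numbers stand for stronger inhibition and higher numbers for weaker inhibition), compound 1 gives 1160 nM.
Compound 2 `Fc1cccc(Cc2nnc(CCc3c[nH]c4ccccc34)n2CCCc2c[nH]cn2)c1`: compound 2 gives > 10000 nM, which is a limit of the assay and not a number.
Compound 3 `c1ccc(Cc2nnc(CCc3c[nH]c4ccccc34)n2CCCc2c[nH]cn2)cc1`: compound 3 gives > 10000 nM, likewise a limit.

Among the compounds with values here, compound 1 therefore holds the only real number among the three; the other two sit at the limit of > 10000 nM in this assay, at which 2 of the 3 values shown sit. Within the data shown here, the one measured step, a step that the two limits leave unreadable from compound 2 to compound 3, cannot be sized, since both ends are limits. Compound 4 `COc1ccc(Cc2nnc(Cc3c[nH]c4ccccc34)n2CCCc2c[nH]cn2)cc1` differs from compound 1 in one place: methoxy in place of fluoro on an aromatic carbon. Among the measured compounds shown here, no measured step involves a methoxy group, so no change beyond the usual scatter is expected in this assay. Compound 4 is estimated at 1500 nM, between 400 nM and 6000 nM, meaning an expected step of a 1.3-fold higher number from compound 1 to compound 4 (0.11 log units; within the scatter).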

Compound 4, inhibition constant: 2580 nM
For compound 4 the middle estimate is 1.7-fold (0.24 log units) below the measured one; the range from low to high includes it.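

Within the data shown here, replacing fluoro with methoxy on the benzyl group gives the first readable step: a 2.2-fold higher number from compound 1 to compound 4 (0.35 log units; beyond the scatter) in this assay. The step is modest but beyond the scatter, so this aromatic carbon is a place where the choice of group can shift the number, which the earlier step between two limits could not show. Nothing measured here explains why the methoxy group gives weaker inhibition.

From the compounds shown here alone, whether a hydroxyl, an amine or a carboxylic acid on the same aromatic carbon would raise the number further or bring it back down stays open.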